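This account rests on a few compounds, and the source may have more. Where it says the series, first, only, none or still open, it means among the compounds named here.

In a functional assay on NCI-H460 cells (Homo sapiens) (on this read-out higher numbers stand for an effect only at larger amounts of compound and lower numbers for an effect already at smaller amounts), the measured compounds read as follows:
- Compound 1 `COC(=O)N1N=C(c2ccc(N(C)C)cc2)OC1c1cc(OC)c(OC)c(OC)c1` gives 106 uM
- Compound 2 `COc1cc(C2OC(c3ccc(N(C)C)cc3)=NN2C(=O)CN=[N+]=[N-])cc(OC)c1OC` gives 0.53 uM
- Compound 3 `COc1cc(C2OC(c3ccc(N(C)C)cc3)=NN2C(=O)CN(C)C)cc(OC)c1OC` gives 74 uM

Compound 3 stands at 74 uM in the upper pair of the three numbers. The gap is a 1.4-fold lower number from compound 1 to compound 3 (0.16 log units; within the scatter) on one side and a 140-fold higher number from compound 2 to compound 3 (2.14 log units; beyond the scatter) on the other. Compound 4 `COc1cc(C2OC(c3ccc(N(C)C)cc3)=NN2C(=O)CN)cc(OC)c1OC` has amino in place of dimethylamino on a saturated chain carbon bound to a carbonyl carbon. Among the steps at this place, only those involving azido were large, as in a 200-fold lower number from compound 1 to compound 2 (2.30 log units; beyond the scatter) and no amino compound has been measured. The estimated step is a 1.5-fold lower number from compound 3 to compound 4 (0.17 log units; within the scatter) and no change beyond the scatter is expected in this assay here. Compound 4 is expected at 50 uM within a range from 10 uM to 150 uM as an estimate.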

Compound 4, concentration for half-maximal effect: 0.66 uM
Compound 4: the middle estimate sits 76-fold (1.88 log units) above what was measured, and the stated range ends above it.
By their numbers in this assay, from the lowest: compounds 2 and 4 (each within the scatter of the next); then compounds 3 and 1 (each within the scatter of the next).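

In this assay the large change at this position is no longer tied to azido: amino in place of dimethylamino gives a 110-fold lower number from compound 3 to compound 4 (2.05 log units; beyond the scatter) and aminomethyl in place of methoxy gives a 160-fold lower number from compound 1 to compound 4 (2.21 log units; beyond the scatter). Amino and azido on the saturated chain carbon cannot be told apart, with a 1.2-fold higher number from compound 2 to compound 4 (0.10 log units; within the scatter), while dimethylamino stands apart from both. Nothing available explains this difference. On these data alone, whether methylamino, with a single methyl, reads like amino or like dimethylamino stays open, as does whether a longer chain carrying the amino keeps the low number.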